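A few compounds are considered here, and "the series" means these few. Any claim that something is new, unique, unknown or untested is made for them only; others in the source may bear on it.

Measured so far in an ADME assay on the whole organism for pharmacokinetics, with Rattus norvegicus as the target; on this read-out higher numbers stand for wider distribution into tissues and lower numbers for narrower distribution:

Compound 1 `O=S(=O)(c1ccc(C(F)(F)F)cc1)c1cc(F)c(O)c2ncccc12` gives 3.8 L/kg
Compound 2 `Cc1ccc(S(=O)(=O)c2cc(F)c(O)c3ncccc23)cc1` gives 1.2 L/kg
Compound 3 `O=S(=O)(c1cc(Cl)c(O)c2ncccc12)C1CCCC1` gives 0.3 L/kg

Of these three, compound 2 holds the second highest number, with compound 1 above it and compound 3 below it, both gaps beyond the scatter. Compound 4 `O=S(=O)(c1cc(F)c(O)c2ncccc12)N1CCCC1` keeps the core of compound 2 and alters only the group on the sulfonyl sulfur, with pyrrolidin-1-yl in place of 4-methylphenyl on a sulfonyl sulfur.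

Going by the values given here, no measured step makes this exact swap. Among the compounds with values here, the one measured step, a 3.2-fold lower number from compound 1 to compound 2 (0.50 log units; beyond the scatter), is modest and concerns methyl in place of trifluoromethyl on an aromatic carbon, so it shows only that a change in this part of the molecule can move the number beyond the scatter. Within the data shown here, compound 3, at 0.3 L/kg, is the only measured compound with a non-aromatic ring on the sulfonyl sulfur, but it differs from compound 2 in more than one place, so it is only a loose guide. A modest fall is therefore expected, rather than none.

The expected change is a 2.0-fold lower number from compound 2 to compound 4 (0.30 log units; within the scatter), a step of similar size to the measured one or smaller. Compound 4 is estimated at 0.6 L/kg, with an expected range from 0.25 L/kg to 1.3 L/kg, and the wide range reflects the lack of a direct precedent.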

Compound 4, volume of distribution at steady state: 2.2 L/kg
Beside the measured number, compound 4's estimate is 3.7-fold (0.56 log units) below it; the measured number lies above the stated range.
By their numbers in this assay, from the lowest: compound 3; then compounds 2, 4 and 1 (each within the scatter of the next, the first and the last beyond it).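

In this assay, replacing 4-methylphenyl with pyrrolidin-1-yl on the sulfonyl sulfur gives a 1.8-fold higher number from compound 2 to compound 4 (0.26 log units; within the scatter), so this exchange of one ring for another leaves the read-out within the usual spread of repeat measurements. The earlier single-place step altered only a small group on the aromatic ring, whereas this one replaces the whole group on the sulfur, showing that an aromatic ring of carbon only at this place is not needed to keep the read-out level with compound 2, at least on the shared core carrying fluorine. Nothing given here explains why the number holds when a non-aromatic ring containing nitrogen enters at this place.

From the compounds shown here alone, one ring at this place is a single example, so it remains open whether a larger ring such as piperidin-1-yl or morpholin-4-yl, or an open chain such as diethylamino, would also stay close to compound 4. Going by these compounds, it is equally open how a pyrrolidin-1-yl ring bearing a charged group, such as a primary amine or a carboxylic acid, would behave in this read-out.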